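Compound 4 against a series held at the limit

This account rests on a few compounds, and the source may have more. Where it says the series, first, only, none or still open, it means among the compounds named here.

Measured in a functional assay on HepG2 cells (Homo sapiens) for antiproliferative activity, read by XTT assay, with a stated time of 72 h (a higher number here means a weaker inhibitor, a lower number a stronger inhibitor), so far:
- compound 1 `Nc1nc(N)c2c(-c3cccs3)cn([C@@H]3O[C@H](CO)[C@@H](O)[C@H]3O)c2n1` gives > 20000 nM as a limit
- compound 2 `Nc1nc2c(c(-c3ccoc3)cn2[C@@H]2O[C@H](CO)[C@@H](O)[C@H]2O)c(=O)[nH]1` gives > 20000 nM as a limit
- compound 3 `Nc1nc2c(c(-c3cccs3)cn2[C@@H]2O[C@H](CO)[C@@H](O)[C@H]2O)c(=O)[nH]1` gives > 20000 nM as a limit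

Compound 3 stands at > 20000 nM as a limit and not as a number. Among the compounds with values here, its neighbours offer no ranking, as the evidence is the limit of > 20000 nM in this assay, at which 3 of the 3 values shown sit, and no measured compound has a numerical value. The next structure is compound 4 `Nc1nc2c(c(-c3cc4ccccc4o3)cn2[C@@H]2O[C@H](CO)[C@@H](O)[C@H]2O)c(=O)[nH]1` with the change 1-benzofuran-2-yl in place of thiophen-2-yl on an aromatic carbon as its only difference, which is 1-benzofuran-2-yl in place of thiophen-2-yl on an aromatic carbon.

Within the data shown here, the single measured step is a step that the two limits leave unreadable from compound 2 to compound 3 and it gives no size to carry over. That step concerns the same kind of substitution, and it stayed at the limit at both ends. No readable step is therefore expected in this assay and a further limit is the likeliest report. The estimated change is a number no higher from compound 3 to compound 4 (the limit leaves the size open) with no direction firmly expected. For compound 4 the expected value is 20000 nM with an estimated range from 8000 nM to 50000 nM in this assay for now.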

Compound 4, half-maximal inhibitory concentration: > 20000 nM
Compound 4: no number, only a limit; the forecaster's own chance of this, stated with the estimate: 85%; the middle value lies on the limit itself.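

Compound 4 gives > 20000 nM in this assay, a limit and not a number, and the steps to it from compound 2 and compound 3 cannot be read: the limit of > 20000 nM in this assay, at which 4 of the 4 values shown sit.

The compounds shown leave open how these groups rank against one another in this assay, since none has a numerical value.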